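Isopropoxy to sec-butoxy in a series that shows only limits

The source may report more compounds than this note shows. Statements on the series, on what has been measured and on what is new or still open speak of the compounds shown alone.

Compound 3 `Cc1cc(CCC(=O)O)ccc1-c1noc(-c2ccc(OC(C)C)c(C#N)c2)n1` carries a cyano group on an aromatic carbon of the ring that also bears the isopropoxy group. In a functional assay on CHO cells with sphingosine 1-phosphate receptor 2 (Homo sapiens) as the target, read by GTPgammaS binding (a lower number here means that less compound is needed, a higher number that more compound is needed for the effect), compound 3 gives > 10000 nM, which is a limit of the assay rather than a number. Compound 1 `Cc1cc(CCC(=O)O)ccc1-c1noc(-c2ccc(OC(C)C)c(F)c2)n1` has fluoro in that place. In this assay compound 1 gives > 10000 nM, again a limit. Compound 2 `Cc1cc(CCC(=O)O)ccc1-c1noc(-c2ccc(OC(C)C)c(Br)c2)n1` has bromo there. In this assay compound 2 gives > 10000 nM, also a limit. All three therefore sit together at the limit of > 10000 nM in this assay, at which 3 of the 3 values shown sit. The steps between them, a step that the two limits leave unreadable from compound 1 to compound 2, a step that the two limits leave unreadable from compound 1 to compound 3 and a step that the two limits leave unreadable from compound 2 to compound 3, cannot be read in size, since each end is a limit.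

Compound 4 `CC[C@H](C)Oc1ccc(-c2nc(-c3ccc(CCC(=O)O)cc3C)no2)cc1C#N` is not yet measured. It differs from compound 3 by methyl in place of hydrogen on a saturated chain carbon, two bonds along the chain from an oxygen on an aromatic ring, a change that turns isopropoxy into sec-butoxy. Going by the values given here, none of the measured steps touches this part of the molecule; they only exchange the group on the aromatic carbon, and none of them gave a readable number. The expectation therefore rests on a single fixed point: compound 3 gives only a limit. With nothing showing that one added carbon on the chain would bring the value into the readable range, compound 4 is expected to remain at the limit, so the expected step that the limit leaves unreadable from compound 3 to compound 4 is small. The estimate for compound 4 in this assay is 15000 nM, within a range from 5000 nM to 50000 nM.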

Compound 4, half-maximal effective concentration: > 10000 nM
Compound 4: only a limit was reported; the forecaster's own chance of this, stated with the estimate: 80%; the middle value is on the limit's open side.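

In this assay compound 4 gives > 10000 nM, a limit of the assay and not a number. Compound 3 also gives only a limit, so the step between compound 3 and compound 4 cannot be read in size. All the compounds shown sit together: the limit of > 10000 nM in this assay, at which 4 of the 4 values shown sit.

The compounds shown leave open whether changing isopropoxy to sec-butoxy, or exchanging the group on the aromatic carbon, alters the value at all.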